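A Fluoro-Methoxy Amide Variant of Compound 1

The source may report more compounds than this note shows. Statements on the series, on what has been measured and on what is new or still open speak of the compounds shown alone.

Compound 1 `O=C(Nc1cccc(-c2oc3cc(-c4ccc(F)cc4)ccc3c(=O)c2O)c1)c1ccc(Cl)cc1` was tested in a functional assay on HCC1937 cells (Homo sapiens) for antiproliferative activity, read by CCK-8 assay, with a stated time of 72 h (on this read-out higher numbers stand for weaker inhibition and lower numbers for stronger inhibition), where compound 1 gives 4030 nM. Among the three measured analogues this is the lowest number, yet compound 2 `O=C(Nc1cccc(-c2oc3cc(-c4ccc(F)cc4)ccc3c(=O)c2O)c1)c1ccc(F)cc1F` with 6980 nM and compound 3 `Cc1cc(C(=O)Nc2cccc(-c3oc4cc(-c5ccc(F)cc5)ccc4c(=O)c3O)c2)ccc1F` with 5420 nM both lie within the scatter of it, so no order among the three can be read. Compound 4 `COc1ccc(C(=O)Nc2cccc(-c3oc4cc(-c5ccc(F)cc5)ccc4c(=O)c3O)c2)c(F)c1` differs from compound 1 by 2-fluoro-4-methoxyphenyl in place of 4-chlorophenyl on a carbonyl carbon. The steps of a 1.7-fold higher number from compound 1 to compound 2 (0.24 log units; within the scatter) and a 1.3-fold higher number from compound 1 to compound 3 (0.13 log units; within the scatter) bear on this change, as each exchanges the ring on the carbonyl carbon, and both stayed within the scatter. Compound 4 is therefore expected to show no step beyond the scatter, a 1.2-fold higher number from compound 1 to compound 4 (0.09 log units; within the scatter), with an estimate of 5000 nM between 2500 nM and 12000 nM.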

Compound 4, half-maximal inhibitory concentration: 24500 nM
Compound 4: the middle estimate sits 4.9-fold (0.69 log units) below what was measured; measured number outside the range, above it.
By their numbers in this assay, from the lowest: compounds 1, 3 and 2 (each within the scatter of the next); then compound 4.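

In this assay, among the compounds shown here, the ring on the carbonyl carbon proves less tolerant of change than the earlier compounds suggested: 2-fluoro-4-methoxyphenyl gives a 6.1-fold higher number from compound 1 to compound 4 (0.78 log units; beyond the scatter) and a 4.5-fold higher number from compound 3 to compound 4 (0.66 log units; beyond the scatter), the first steps at this position beyond the scatter. For the compounds shown here, the single exchange of methoxy for fluoro on an aromatic carbon gives a 3.5-fold higher number from compound 2 to compound 4 (0.55 log units; beyond the scatter), so here the rise in the number goes with the methoxy group. As far as these compounds go, whether 4-methoxyphenyl without the fluoro, or an amine in place of the methoxy, would give a step of this size stays open. No measurement shown explains this rise.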